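The compounds below may be only part of what the source reports. "The series", "measured", "known", "first", "only" and "open" are said of these compounds alone.

The three measured compounds and their values in an ADME assay on Vero cells (Chlorocebus sabaeus) for cytotoxicity, read by MTT assay, with a stated time of 72 h; on this read-out lower numbers stand for stronger inhibition and higher numbers for weaker inhibition:

Compound 1, `Cn1cc([N+](=O)[O-])cc1-c1nnc(-c2ccco2)o1`: 191000 nM
Compound 2, `Cn1cc([N+](=O)[O-])cc1-c1nnc(-c2ccc(Cl)cc2Cl)o1`: 387000 nM
Compound 3, `Cn1cc([N+](=O)[O-])cc1-c1nnc(C2CCCNC2)o1`: 611000 nM

Compound 3 stands at the highest number of the three in this assay. Its nearest neighbour is compound 2, and the gap between those two values lies within the scatter, so no order can be read between them. Among the measured compounds shown here, the only counted step, a 3.2-fold higher number from compound 1 to compound 3 (0.51 log units; beyond the scatter), is beyond the scatter and modest in size.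

Compound 4, `Cn1cc([N+](=O)[O-])cc1-c1nnc(-c2ccccc2Br)o1`, is the next compound to be measured. It differs from compound 3 in one place: 2-bromophenyl in place of piperidin-3-yl on an aromatic carbon. The step from compound 1 to compound 3 bears on this change, since it also exchanges an aromatic ring for piperidin-3-yl at the same place, but in the opposite direction; read backwards it points toward a somewhat lower number for compound 4. Compound 2, which carries an aromatic ring bearing halogens at that place, gives a number within the scatter of compound 3, which tempers that expectation. Compound 4 is therefore expected to show a modest step downward in this assay, a 2.0-fold lower number from compound 3 to compound 4 (0.31 log units; beyond the scatter). The estimate for compound 4 is 300000 nM, with a range from 150000 nM to 600000 nM.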

Compound 4, half-maximal inhibitory concentration: 303000 nM
The estimate for compound 4 lay 1.0-fold (0.00 log units) below the measured number; the measured number falls inside the stated range.
By their numbers in this assay, from the lowest: compounds 1, 4, 2 and 3 (each within the scatter of the next, the first and the last beyond it).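

In this assay, 2-bromophenyl in place of piperidin-3-yl on this aromatic carbon gives a 2.0-fold lower number from compound 3 to compound 4 (0.30 log units; within the scatter), so exchanging a six-membered non-aromatic ring with its hydrogen-bond donor and acceptor for a six-membered aromatic ring of carbon only, bearing bromine, does not separate the two compounds. Among the compounds shown here, the exchange of furan-2-yl for 2-bromophenyl at the same place gives a 1.6-fold higher number from compound 1 to compound 4 (0.20 log units; within the scatter), so the new compound cannot be told apart from either end of the one earlier step that lay beyond the scatter, and that step does not divide the groups at this place into two clear classes. No evidence is available that bears on why the numbers fall as they do.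

Every group shown at this place is a ring, so the compounds leave open what an open-chain amine, a carboxylic acid or a longer alkyl chain would give there. They also leave open whether unsubstituted phenyl would stand with 2-bromophenyl, and whether any group at this place could bring the number far from those seen here.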